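The source may hold more compounds than are shown below. What is called first, only, known or untested is meant among the compounds shown, and "the series" means these compounds.

In a functional assay on KG-1 cells (Homo sapiens) for cytotoxicity, read by luminescence and CellTiter-Glo, with a stated time of 3 days (a lower number here means a stronger inhibitor, a higher number a weaker inhibitor), compound 2 (`N#Cc1ccc(NC(=O)c2ccccc2O)cc1`) gives 5370 nM and holds the higher of the two numbers, while compound 1 (`O=C(Nc1ccc(C(F)(F)F)cc1)c1cc(Br)ccc1O`) gives 610 nM, a gap beyond the scatter. Compound 3 (`N#Cc1ccc(NC(=O)c2cc(Br)ccc2O)cc1`) departs from compound 2 in one place (bromo in place of hydrogen on an aromatic carbon), with bromo in place of hydrogen on an aromatic carbon, para to a hydroxy group. Within the data shown here, no measured step in one place is available in this assay, so the only guide is compound 1, which also carries bromo and gives 610 nM as its number. A drop beyond the scatter is expected (a 5.4-fold lower number from compound 2 to compound 3 (0.73 log units; beyond the scatter)). For compound 3 the estimated value is 1000 nM (range 300 nM to 3500 nM).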

Compound 3, half-maximal inhibitory concentration: 1290 nM
Compound 3: the middle estimate sits 1.3-fold (0.11 log units) below what was measured, and the stated range covers the measured number.
By their numbers in this assay, from the lowest: compound 1; then compound 3; then compound 2.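

In this assay, among these compounds, bromo in place of hydrogen on an aromatic carbon, para to a hydroxy group, gives a 4.2-fold lower number from compound 2 to compound 3 (0.62 log units; beyond the scatter), the first direct reading of this change at this position. With bromo held constant, cyano in place of trifluoromethyl on an aromatic carbon gives a 2.1-fold higher number from compound 1 to compound 3 (0.33 log units; beyond the scatter), so a change at either place moves the number beyond the scatter. No evidence at hand bears on the reason for either step. The compounds shown leave open whether chloro or an amine at this position would give a similar step, and whether bromo would give the same step alongside trifluoromethyl.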